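From Dimethylphenyl to Ethylphenyl on a Sulfonamide Nitrogen

The source may report more compounds than this note shows. Statements on the series, on what has been measured and on what is new or still open speak of the compounds shown alone.

Compound 1 `O=C1NCCN1c1ccc(S(=O)(=O)Nc2cccc(Oc3ccccc3)c2)cc1`: 200 nM
Compound 2 `Cc1cccc(NS(=O)(=O)c2ccc(N3CCNC3=O)cc2)c1C`: 190 nM
Compound 3 `Cc1cc(C)cc(NS(=O)(=O)c2ccc(N3CCNC3=O)cc2)c1`: 82 nM

All three were tested in a functional assay on HT-29 cells (Homo sapiens) for antiproliferative activity, read by sulforhodamine B assay, with a stated time of 48 h; on this read-out lower numbers stand for stronger inhibition and higher numbers for weaker inhibition. Compound 3 shows the lowest of the three numbers. Its nearest neighbour is reached by the step of a 2.3-fold lower number from compound 2 to compound 3 (0.36 log units; beyond the scatter), which lies beyond the scatter, and compound 1 at 200 nM sits slightly further away, also beyond the scatter. On these three numbers, compound 3 is the strongest inhibitor.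

Compound 4 `CCc1cccc(NS(=O)(=O)c2ccc(N3CCNC3=O)cc2)c1` has not yet been measured. It differs from compound 3 in one place: 3-ethylphenyl in place of 3,5-dimethylphenyl on a sulfonamide nitrogen. Within the data shown here, the only measured step that touches the same position is the one from compound 2 to compound 3, where rearranging two methyl groups on the same ring gave a 2.3-fold lower number from compound 2 to compound 3 (0.36 log units; beyond the scatter). Among the measured compounds shown here, no measured pair compares one ethyl group with two methyl groups, so the direction of the new step is uncertain. The rearrangement in the earlier step changed the number only modestly, so a step of similar or smaller size is expected here, with a somewhat higher number slightly more likely than a lower one. For compound 4 the expected result in this assay is 130 nM, with a range of 55 nM to 300 nM, meaning an estimated step of a 1.6-fold higher number from compound 3 to compound 4 (0.20 log units; within the scatter).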

Compound 4, half-maximal inhibitory concentration: 110 nM
Estimate against measurement, compound 4: 1.2-fold (0.07 log units) above; the range from low to high includes it.
By their numbers in this assay, from the lowest: compounds 3, 4, 2 and 1 (each within the scatter of the next, the first and the last beyond it).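

In this assay, replacing 3,5-dimethylphenyl with 3-ethylphenyl on the sulfonamide nitrogen gives a 1.3-fold higher number from compound 3 to compound 4 (0.13 log units; within the scatter) and so shows that these two groups, which have the same atoms joined differently, cannot be told apart on this read-out. The new group also cannot be separated from the two other groups tested at this position: the change from 2,3-dimethylphenyl gives a 1.7-fold lower number from compound 2 to compound 4 (0.24 log units; within the scatter) and the change from phenoxy on the aromatic carbon gives a 1.8-fold lower number from compound 1 to compound 4 (0.26 log units; within the scatter), even though the earlier step between the two dimethylphenyl groups lies beyond the scatter. No supporting measurement is available to explain why these steps are small.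

The compounds shown leave open whether a longer chain such as propyl, or an amine or a carboxylic acid, in place of the ethyl group would keep the number in this range. They also leave open how far the result depends on the ethyl group itself, since a phenyl ring with a single methyl group or with no added group at all does not appear among them.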